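A few compounds are considered here, and "the series" means these few. Any claim that something is new, unique, unknown or untested is made for them only; others in the source may bear on it.

Compound 1 `CC(C)=CCC[C@]1(C)/C=C/[C@@H](OC(=O)C=C(C)C)[C@](C)(O)/C=C/C(=O)/C(C(=O)O)=C\C1` carries a carboxy group on its core. In a functional assay on SMMC-7721 cells (Homo sapiens) for antiproliferative activity, read by MTT assay, with a stated time of 48 h (a higher number here means a weaker inhibitor, a lower number a stronger inhibitor), compound 1 gives only a limit of the assay, > 10000 nM, and no number. Compound 2 `CC(C)=CCC[C@]1(C)/C=C/[C@@H](OC(=O)C=C(C)C)[C@](C)(O)CCC(=O)/C(CO)=C\C1` is a close relative of compound 1. In this assay compound 2 likewise reaches only a limit, > 40000 nM. Compound 3 `CC(C)=CCC[C@]1(C)/C=C/[C@@H](OC(=O)C=C(C)C)[C@](C)(O)/C=C/[C@H](O)/C(CO)=C\C1` is a further relative. In this assay compound 3 also stops at a limit, > 40000 nM. All three measured compounds thus end at a limit rather than at a number: one of them at the limit of > 10000 nM in this assay, at which 1 of the 3 values shown sits, and two of them at the limit of > 40000 nM in this assay, at which 2 of the 3 values shown sit. Compound 1 therefore stands at the lower of the two limits, and nothing in these figures ranks it against compound 2 or compound 3.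

Compound 4 `CCN(CC)C(=O)/C1=C/C[C@](C)(CCC=C(C)C)/C=C/[C@@H](OC(=O)C=C(C)C)[C@](C)(O)/C=C/C1=O` has not yet been measured in this assay. It differs from compound 1 in one place: diethylamino in place of hydroxy on a carbonyl carbon. Within the data shown here, no measured pair in this set shows the effect of such a change, so its size and direction remain open. Because compound 1 itself sits at a limit, > 10000 nM, the step can only be judged loosely. The expected step is a step that the limit leaves unreadable from compound 1 to compound 4. Compound 4 is estimated to give 15000 nM, in a range from 3000 nM to 60000 nM.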

Compound 4, half-maximal inhibitory concentration: 13800 nM
Compound 4: middle estimate off by 1.1-fold (0.04 log units), on the high side; low and high end bracket the measured number.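

In this assay, among these compounds, compound 1 has only a limit, > 10000 nM, and not a number, so no step from it to compound 4 can be read. The compounds shown leave open how far, and in which direction, diethylcarbamoyl in place of carboxy on the shared core shifts antiproliferative activity.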